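The source may report more compounds than this note shows. Statements on the series, on what has been measured and on what is new or still open speak of the compounds shown alone.

Measured in a functional assay on A549 cells (Homo sapiens) for cytotoxicity, read by MTT assay, with a stated time of 48 h; a lower number here means a stronger inhibitor, a higher number a weaker inhibitor:
- compound 1 `CCOC(=O)[C@@]1(C(=O)Nc2ccccc2)C[C@@H]1c1cc(OC)c(OC)c(OC)c1`: > 100000 nM (a limit)
- compound 2 `CCOC(=O)[C@]1(C(=O)NCc2ccc(C)cc2)C[C@H]1c1cc(OC)c(OC)c(OC)c1`: 13300 nM

Compound 1 gives > 100000 nM, which is a limit of the assay and not a number. For the measured compounds named here, compound 2, at 13300 nM, therefore holds the only true number in this assay, and it has no measured neighbour that differs from it in one place.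

The next compound is compound 3 `CCOC(=O)[C@@]1(C(=O)NCc2ccc(C)cc2)C[C@@H]1c1cc(OC)c(OC)c(OC)c1`, still to be measured in this assay. The change is purely one of configuration: the two compounds have the same atoms and bonds and differ only in configuration as drawn: 2 of 2 stereo elements differ (all stereocentres are inverted: mirror images); a stereocentre at a saturated ring carbon is drawn R in compound 2 and S in compound 3; a stereocentre at a saturated ring carbon is drawn S in compound 2 and R in compound 3. The atoms and bonds stay the same, and compound 3 is the mirror image of compound 2.

Going by the values given here, the series holds no measured mirror-image pair, so neither the size nor the direction of this step can be read from the data. The expectation is therefore a modest one, with only a slight lean toward weaker inhibition, and the expected move, a 1.5-fold higher number from compound 2 to compound 3 (0.18 log units; within the scatter), is not clearly beyond the scatter. A result at the limit of the assay remains possible. For compound 3 the estimated value is 20000 nM, with an expected range from 6000 nM to 80000 nM.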

Compound 3, half-maximal inhibitory concentration: > 100000 nM
Compound 3: a limit, no number (the forecaster's own chance of this, stated with the estimate: 20%); middle value at least 5.0-fold (0.69 log units) from the limit.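

In this assay, the mirror-image pair gives the series its first readable step: an at least 7.5-fold higher number from compound 2 to compound 3 (0.87 log units; beyond the scatter), a change toward weaker inhibition that lies beyond the scatter. Compound 3 gives > 100000 nM, which is a limit of the assay and not a number, so the step has a lower bound but no measured size. Configuration at the two stereocentres on the saturated ring therefore matters in this 4-methylbenzyl amide, and the shift can be assigned to it alone because no other structural change is present: the fact that compounds 2 and 3 differ only in the configuration as drawn.

The step from phenyl to 4-methylbenzyl between compound 1 and compound 3 cannot be read because both of its ends are limits, which leaves the effect of this amide substituent in the configuration of compound 3 unresolved: the limit of > 100000 nM in this assay, at which 2 of the 3 values shown sit. Also open, going by these compounds, are whether the mirror image of compound 1 gives a true number and whether a carboxylic acid in place of the ethyl ester, or a longer chain between the amide nitrogen and the aryl ring, keeps a measurable value in the configuration of compound 2.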